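A few compounds are considered here, and "the series" means these few. Any claim that something is new, unique, unknown or untested is made for them only; others in the source may bear on it.

Compound 2, with the structure `COc1ccc(Sc2nc3cc(N)cc(N)c3nc2-c2ccccc2)cc1`, is known in a functional assay on OVCAR-4 cells (Homo sapiens) for inhibition, read by sulforhodamine B assay, with a stated time of 48 h (on this read-out higher numbers stand for lower toxicity in this test and lower numbers for higher toxicity in this test), only by a limit: in that test compound 2 gives < 100000 nM, which is a limit of the measurement rather than a number. Compound 1, `Nc1cc(N)c2nc(-c3ccccc3)c(Oc3ccc(Cl)c(Cl)c3)nc2c1`, carries the same kind of result, as in this assay compound 1 gives < 100000 nM, again a limit. Among the compounds with values here, the one step among the measured pair, a step that the two limits leave unreadable from compound 1 to compound 2, is therefore of unreadable size. The change that leads to compound 3, `Nc1cc(N)c2nc(-c3ccccc3)c(Sc3ccc(F)cc3)nc2c1`, is fluoro in place of methoxy on an aromatic carbon. Within the data shown here, no measured step bears on this change with a readable size: both values shown sit at the limit of < 100000 nM in this assay, at which 2 of the 2 values shown sit, so the step from compound 2 to compound 3 in this assay cannot be anchored to anything beyond that limit. Among the measured compounds shown here, with nothing to point in either direction, the account expects no step that could be told from the scatter, and compound 3 is estimated at 30000 nM, within 5000 nM to 100000 nM. The step this estimate means, a step that the limit leaves unreadable from compound 2 to compound 3, is expected to be flat, with a good chance that compound 3 too is reported only as a limit.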

Compound 3, concentration lethal to 50% of the cells: < 100000 nM
Compound 3 gave a limit, no number; the forecaster's own chance of this, stated with the estimate: 80%; the middle value is on the limit's open side.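

In this assay compound 3 gives < 100000 nM, which is a limit and not a number. No new step can be read among compound 1, compound 2 and compound 3: the limit of < 100000 nM in this assay, at which 3 of the 3 values shown sit. The compounds shown leave open how far apart these three truly lie, and whether fluoro in place of methoxy changes the result at all.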